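Ethyl to tert-Butyl on the Pendant Ring

A few compounds are considered here, and "the series" means these few. Any claim that something is new, unique, unknown or untested is made for them only; others in the source may bear on it.

Compound 1 `NS(=O)(=O)c1ccc(-c2nc3cc([N+](=O)[O-])ccc3[nH]2)cc1` gives > 31600 nM in a functional assay for antagonist activity at Neuropeptides B/W receptor type 1 (Homo sapiens), read by cAMP accumulation (a higher number here means a weaker inhibitor, a lower number a stronger inhibitor), a limit of the assay.
Compound 2 `O=[N+]([O-])c1ccc2[nH]c(-c3ccc(C(F)(F)F)cc3)nc2c1` gives > 31600 nM in this assay, also a limit.
Compound 3 `CCc1ccc(-c2nc3cc([N+](=O)[O-])ccc3[nH]2)cc1` gives 1020 nM in this assay.

Compound 3 is thus the only one of the three with a number rather than a limit, so it stands alone at the potent end of what is known. Compound 4 `CC(C)(C)c1ccc(-c2nc3cc([N+](=O)[O-])ccc3[nH]2)cc1` differs from it by tert-butyl in place of ethyl on an aromatic carbon. The measured steps that touch this position are an at least 30-fold lower number from compound 1 to compound 3 (1.49 log units; beyond the scatter) and an at least 30-fold lower number from compound 2 to compound 3 (1.49 log units; beyond the scatter), both large; the step that the two limits leave unreadable from compound 1 to compound 2 cannot be read. None of them exchanges one alkyl group for another, so little can be inferred for the present change. The expected step is a 1.0-fold lower number from compound 3 to compound 4 (0.01 log units; within the scatter), no larger than the scatter. Compound 4 is therefore expected to give 1000 nM, between 250 nM and 4000 nM.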

Compound 4, half-maximal inhibitory concentration: 3180 nM
For compound 4 the middle estimate is 3.2-fold (0.50 log units) below the measured one; low and high end bracket the measured number.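

Exchanging ethyl for tert-butyl, the only swap shown of one alkyl group for another, gives a 3.1-fold higher number from compound 3 to compound 4 (0.49 log units; beyond the scatter) in this assay, so these two alkyl groups are not interchangeable at this position. The tert-butyl group still gives a measured number, with an at least 9.9-fold lower number from compound 2 to compound 4 (0.99 log units; beyond the scatter) and an at least 9.9-fold lower number from compound 1 to compound 4 (0.99 log units; beyond the scatter). Those two steps are bounded on one side only: the limit of > 31600 nM in this assay, at which 2 of the 4 values shown sit.

The step between compound 1 and compound 2 cannot be read. From the compounds shown here alone, whether methyl, isopropyl or a longer chain would give a stronger inhibitor than ethyl remains open, as does the effect of an amine here.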